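Fluoroquinolone-type topoisomerase 1 series: amine exchange at the fluoro-bearing ring

The source may hold more compounds than are shown below. What is called first, only, known or untested is meant among the compounds shown, and "the series" means these compounds.

Measured compounds:
compound 1 `O=C(O)c1cn(Cc2ccc(-c3ccccc3)cc2)c2cc(N3CC4CNCC4C3)c(F)cc2c1=O`, 33300 nM
compound 2 `O=C(O)c1cn(Cc2ccc(-n3cccn3)cc2)c2cc(NC[C@@H]3CCNC3)c(F)cc2c1=O`, 200000 nM

In an assay on isolated protein for inhibition of DNA topoisomerase 1 (Homo sapiens), with a stated time of 15 min (on this read-out lower numbers stand for stronger inhibition and higher numbers for weaker inhibition), compound 2 gives the highest of the two numbers, and compound 1 gives 33300 nM, the gap to compound 2 lying beyond the scatter. Among the measured compounds shown here, compound 3 `O=C(O)c1cn(Cc2ccc(-n3cccn3)cc2)c2cc(N3CC4CNCC4C3)c(F)cc2c1=O` carries the change (a group of 8 heavy atoms (6 carbon, 2 nitrogen; 2 five-membered non-aromatic rings with 1 hetero atom each) in place of a group of 7 heavy atoms (5 carbon, 2 nitrogen; one five-membered non-aromatic ring with 1 hetero atom), on an aromatic carbon); the ring system that enters is the one already present in compound 1, while the side chain on the other nitrogen is that of compound 2. For the measured compounds named here, no measured pair isolates this exchange, so the expected step of a 3.3-fold lower number from compound 2 to compound 3 (0.52 log units; beyond the scatter) is a move towards a lower number, leaning on compound 1 with 33300 nM. Compound 3 is estimated at 60000 nM, within 20000 nM to 200000 nM.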

Compound 3, half-maximal inhibitory concentration: 173000 nM
For compound 3 the middle estimate is 2.9-fold (0.46 log units) below the measured one, and the stated range covers the measured number.
By their numbers in this assay, from the lowest: compound 1; then compounds 3 and 2 (each within the scatter of the next).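

In this assay, exchanging ((pyrrolidin-3-yl)methyl)amino for the group of two five-membered non-aromatic rings, on the aromatic carbon ortho to a fluoro group, gives a 1.2-fold lower number from compound 2 to compound 3 (0.06 log units; within the scatter), so this amine change does not separate the two. Among the compounds shown here, with that ring group held constant, 1H-pyrazol-1-yl in place of phenyl gives a 5.2-fold higher number from compound 1 to compound 3 (0.72 log units; beyond the scatter), the only single-place step here beyond the scatter. No supporting data explain either result.

From the compounds shown here alone, whether the amine exchange reads the same with phenyl in place of 1H-pyrazol-1-yl remains open. So does the outcome with piperazine on that aromatic carbon.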